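1,3-Benzothiazol-2-yl in place of 1H-benzimidazol-2-yl

The source may report more compounds than this note shows. Statements on the series, on what has been measured and on what is new or still open speak of the compounds shown alone.

For the measured compounds named here, in a functional assay on cells (Homo sapiens) for antiproliferative activity, read by MTT assay, with a stated time of 48 h (a lower number here means a stronger inhibitor, a higher number a weaker inhibitor), compound 1 `CN(C)CCCn1c(N)c(-c2nc3ccccc3[nH]2)c2nc(C#N)c(C#N)nc21` gives 1820 nM, the only actual number so far. Compound 2 `N#Cc1nc2c(-c3nc4ccccc4[nH]3)c(N)n(CCCO)c2nc1C#N` gives only a limit, > 50000 nM. Going by the values given here, the sole measured step, an at least 27-fold higher number from compound 1 to compound 2 (1.43 log units; beyond the scatter), is large and beyond the scatter, but it concerns hydroxy in place of dimethylamino on the chain and so sets no size for the present change. Compound 3 `CN(C)CCCn1c(N)c(-c2nc3ccccc3s2)c2nc(C#N)c(C#N)nc21` carries 1,3-benzothiazol-2-yl in place of 1H-benzimidazol-2-yl on an aromatic carbon. In this assay a modest move towards a higher number is expected, with a wide range. The expected step is a 1.6-fold higher number from compound 1 to compound 3 (0.22 log units; within the scatter). Compound 3 is estimated at 3000 nM, within 800 nM to 12000 nM.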

Compound 3, half-maximal inhibitory concentration: 2930 nM
Compound 3: middle estimate off by 1.0-fold (0.01 log units), on the high side, within the range that was stated.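

In this assay, the exchange gives a 1.6-fold higher number from compound 1 to compound 3 (0.21 log units; within the scatter), so this aromatic carbon of the shared core takes 1,3-benzothiazol-2-yl in place of 1H-benzimidazol-2-yl without a readable change. The hydrogen-bond donor of 1H-benzimidazol-2-yl is therefore not required here, at least for this pair carrying the 3-(dimethylamino)propyl group. No measured property at hand bears on this step.

Open, from the compounds shown here alone, is whether a smaller group such as phenyl, or 1,3-benzoxazol-2-yl, would hold the value at this carbon. Also open, going by these compounds, is how a 3-hydroxypropyl chain behaves alongside 1,3-benzothiazol-2-yl.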